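Swapping piperidine for morpholine on the amide of compound 3

A few compounds are considered here, and "the series" means these few. Any claim that something is new, unique, unknown or untested is made for them only; others in the source may bear on it.

Compound 1 `Cc1cccc(NC(=O)/C(C#N)=C/c2cc(O)c(O)c([N+](=O)[O-])c2)c1` in a functional assay on Bel-7402 cells (Homo sapiens) for antiproliferative activity, read by MTT assay (a higher number here means a weaker inhibitor, a lower number a stronger inhibitor), gives 13.1 ug/mL.
Compound 2 `N#C/C(=C\c1cc(O)c(O)c([N+](=O)[O-])c1)C(=O)Nc1cccc(Cl)c1` gives 40.1 ug/mL.
Compound 3 `N#C/C(=C\c1cc(O)c(O)c([N+](=O)[O-])c1)C(=O)N1CCCCC1` gives only a limit of the assay, > 100 ug/mL.

Compound 3 thus stands at the weak end of the three measured compounds; its value is the limit of the assay, shared by one of the three values shown (the limit of > 100 ug/mL in this assay, at which 1 of the 3 values shown sits). Compound 4 `N#C/C(=C\c1cc(O)c(O)c([N+](=O)[O-])c1)C(=O)N1CCOCC1` differs from compound 3 in one place: morpholin-4-yl in place of piperidin-1-yl on a carbonyl carbon.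

Within the data shown here, no measured step changes the piperidin-1-yl ring itself. The steps that touch the amide both lead into compound 3: an at least 7.6-fold higher number from compound 1 to compound 3 (0.88 log units; beyond the scatter) and an at least 2.4-fold higher number from compound 2 to compound 3 (0.39 log units; beyond the scatter). They show that the two aryl amides sit below the limit while the cyclic amide reaches it, but they say nothing about exchanging one cyclic amine for another. With that in mind, no step beyond the scatter is expected from compound 3 to compound 4, a number no higher from compound 3 to compound 4 (the limit leaves the size open), and compound 4 is expected to stay at or near the limit as well. The estimate for compound 4 is 100 ug/mL, with a range from 40 ug/mL to 250 ug/mL.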

Compound 4, half-maximal inhibitory concentration: > 100 ug/mL
Compound 4: no number, only a limit (the forecaster's own chance of this, stated with the estimate: 70%); the middle value sits exactly at the limit.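

In this assay, compound 4 gives > 100 ug/mL, which is a limit of the assay and not a number. Putting morpholin-4-yl on the carbonyl carbon in place of the aryl amino groups gives an at least 7.6-fold higher number from compound 1 to compound 4 (0.88 log units; beyond the scatter) and an at least 2.4-fold higher number from compound 2 to compound 4 (0.39 log units; beyond the scatter), so the gap between the two aryl amides and the cyclic amides now holds for a second ring, one with 2 hetero atoms rather than 1. The step from compound 3 to compound 4 cannot be read, because both compounds sit at the same limit: the limit of > 100 ug/mL in this assay, at which 2 of the 4 values shown sit.

The compounds shown leave open how far beyond the limit compound 3 and compound 4 lie, and so whether the ring exchange matters at all. A piperazine ring or an open-chain amine such as diethylamine on the same carbonyl carbon would show whether the weak result goes with these two rings or with the absence of an aryl group.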